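The source may report more compounds than this note shows. Statements on the series, on what has been measured and on what is new or still open speak of the compounds shown alone.

In a functional assay on CHO cells for agonist activity at Free fatty acid receptor 1 (Homo sapiens), read by FLIPR and calcium flux, in the presence of a further agent that is not named here (a higher number here means that more compound is needed for the effect, a lower number that less compound is needed), the three measured compounds gave the following values:

compound 1 `O=C(O)CCc1ccc(OCc2nc(-c3ccccc3Cl)no2)cc1` gives 1200 nM
compound 2 `COc1cccc(-c2noc(COc3ccc(CCC(=O)O)cc3)n2)c1` gives 2670 nM
compound 3 `Cc1cc(-c2noc(COc3ccc(CCC(=O)O)cc3)n2)ccc1F` gives 2120 nM

All three share one core and differ only in the aromatic group attached to the five-membered ring. Compound 3 stands second highest of the three numbers: its nearest neighbour is compound 2, and the step of a 1.3-fold lower number from compound 2 to compound 3 (0.10 log units; within the scatter) is within the scatter, while the step of a 1.8-fold higher number from compound 1 to compound 3 (0.25 log units; within the scatter) is also within the scatter. Going by the values given here, only the step of a 2.2-fold higher number from compound 1 to compound 2 (0.35 log units; beyond the scatter) is modest but beyond it.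

Compound 4 `O=C(O)CCc1ccc(OCc2nc(-c3cccc(Br)c3)no2)cc1` has not yet been measured. The change from compound 3 is 3-bromophenyl in place of 4-fluoro-3-methylphenyl on an aromatic carbon. Every swap of this aromatic group seen so far moved the number by little, so no step beyond the scatter is expected in this assay, in either direction, and the expected step of a 1.1-fold lower number from compound 3 to compound 4 (0.03 log units; within the scatter) is small. Compound 4 is estimated at 2000 nM, with a range from 900 nM to 4500 nM.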

Compound 4, half-maximal effective concentration: 1260 nM
Estimate against measurement, compound 4: 1.6-fold (0.20 log units) above, within the range that was stated.
By their numbers in this assay, from the lowest: compounds 1, 4, 3 and 2 (each within the scatter of the next, the first and the last beyond it).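

Compound 4 adds a second step beyond the scatter in this assay: bromo in place of methoxy, a change in the substituent alone, gives a 2.1-fold lower number from compound 2 to compound 4 (0.33 log units; beyond the scatter), though this step is only modest. The other two steps, a 1.7-fold lower number from compound 3 to compound 4 (0.23 log units; within the scatter) and a 1.1-fold higher number from compound 1 to compound 4 (0.02 log units; within the scatter), stay within the scatter, so at this place, between two ring nitrogen atoms, 3-bromophenyl cannot be told apart from 4-fluoro-3-methylphenyl or 2-chlorophenyl. Nothing available here explains the difference between bromo and methoxy.

The compounds shown leave open how an amine or a nitrile on the phenyl ring would behave. Also open, on these data alone, is whether the numbers stay this close together if a pyridine or a cyclohexyl group replaces the phenyl ring.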